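A few compounds are considered here, and "the series" means these few. Any claim that something is new, unique, unknown or untested is made for them only; others in the source may bear on it.

In an assay on brain for displacement of a labelled ligand from Sigma non-opioid intracellular receptor 1 (Cavia porcellus) (a higher number here means a weaker inhibitor, a lower number a stronger inhibitor), compound 1, `CC(C)(C)[C@]1(c2ccccc2)OCC[C@H](CCN)O1`, gives only a limit of the assay, > 10000 nM. Compound 2, `C[C@]1(c2ccccc2)OCC[C@H](CCN)O1`, likewise gives only a limit, > 10000 nM. Compound 3, `C[C@@]1(c2ccccc2)OCC[C@@H](CCN)O1`, also gives only a limit, > 10000 nM. Compound 2 thus stands at the limit of this assay, in the same place as the other two measured compounds, and no number separates it from either of them. The step that the two limits leave unreadable from compound 1 to compound 2 cannot be read because of the limit of > 10000 nM in this assay, at which 3 of the 3 values shown sit. The step that the two limits leave unreadable from compound 2 to compound 3 cannot be read either because of the limit of > 10000 nM in this assay, at which 3 of the 3 values shown sit, and the pair is a special case because of the fact that compounds 2 and 3 differ only in the configuration as drawn.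

Compound 4, `NCC[C@H]1CCO[C@@H](c2ccccc2)O1`, differs from compound 2 in one place: hydrogen in place of methyl on a saturated ring carbon. Both measured steps concern the same saturated ring carbon, but neither yields a readable size, so they give no direction for this change, and the data offer nothing to expect a move beyond the scatter. Compound 4 is therefore expected to sit where compound 2 sits, at or close to the limit, a step that the limit leaves unreadable from compound 2 to compound 4 that is an estimate without a measured anchor. Compound 4 is estimated at 15000 nM, with a range from 3000 nM to 60000 nM, most likely reported again only as a limit.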

Compound 4, inhibition constant: > 10000 nM
Compound 4 ended at the assay's limit; the forecaster's own chance of this, stated with the estimate: 70%; the middle value does not contradict the limit.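

In this assay compound 4 gives > 10000 nM, which is a limit of the assay. The steps to compound 4 from compound 1 and compound 2 therefore cannot be read: the limit of > 10000 nM in this assay, at which 4 of the 4 values shown sit.

The compounds shown leave open how strongly any of them inhibits, and whether the group on the saturated ring carbon or the configuration changes this at all.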